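From a Dimethyl Group to a Three-Membered Ring

This account rests on a few compounds, and the source may have more. Where it says the series, first, only, none or still open, it means among the compounds named here.

Among the measured compounds shown here, in a physicochemical assay for solubility, read by LC-MS, in phosphate buffer, with a stated time of 24 h, at pH 7.4 (a higher number here means a more soluble compound, a lower number a less soluble compound), compound 1 (`CC1(C)CC(=O)N(c2cnc(NCc3c(F)ccc4c3CCO4)n3cnnc23)C1`) gives 57000 nM, the higher of the two numbers so far. Compound 2 (`CNC(=O)c1ncc(-c2cnc(NCc3c(F)ccc4c3CCO4)c3cn[nH]c(=O)c23)n1C`) gives 5000 nM, a gap well beyond the usual scatter of repeat measurements. Compound 3 (`O=C1CC2(CC2)CN1c1cnc(NCc2c(F)ccc3c2CCO3)n2cnnc12`) keeps the core of compound 1 but replaces its 4,4-dimethyl-2-oxopyrrolidin-1-yl group, on an aromatic carbon, with a group that has a three-membered non-aromatic ring of carbon only as well as the five-membered non-aromatic ring (a group of 8 heavy atoms (6 carbon, 1 nitrogen, 1 oxygen; one three-membered non-aromatic ring of carbon only, one five-membered non-aromatic ring with 1 hetero atom) in place of a group of 8 heavy atoms (6 carbon, 1 nitrogen, 1 oxygen; one five-membered non-aromatic ring with 1 hetero atom), on an aromatic carbon). For the measured compounds named here, no measured pair of compounds differs in just one place, so this expectation rests on the structural change alone, and the two groups contain the same kinds of atoms in equal number. The expected change is small, a 1.1-fold higher number from compound 1 to compound 3 (0.02 log units; within the scatter), which would not stand out from the scatter. In this assay, compound 3 is estimated to give about 60000 nM, with a likely range of 25000 nM to 140000 nM.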

Compound 3, solubility: 130000 nM
Compound 3: middle estimate off by 2.2-fold (0.34 log units), on the low side; the range from low to high includes it.
By their numbers in this assay, from the lowest: compound 2; then compound 1; then compound 3.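

Among the compounds shown here, this step is the only direct comparison at this position, on an aromatic carbon of the shared core, since compound 1 and compound 2 differ in more than one place. In this assay, replacing the 4,4-dimethyl-2-oxopyrrolidin-1-yl group with the group that carries a three-membered ring of carbon only gives a 2.3-fold higher number from compound 1 to compound 3 (0.36 log units; beyond the scatter) and this modest step lies beyond the usual scatter, although both groups hold the same kinds of atoms in equal number and the same hydrogen-bond donor and acceptor counts. No measurement shown here accounts for the step.

Going by these compounds, whether a group of a different kind at this position, such as an amine or a morpholine ring, would give a higher or lower number remains open. So does whether the same replacement would give a similar step on a different core.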